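This account rests on a few compounds, and the source may have more. Where it says the series, first, only, none or still open, it means among the compounds named here.

Series notes. Three measured compounds share one core and differ only in the aryl group on an aromatic carbon. Compound 1 `CCc1ccc(-c2cn3ccnc3c(-c3ccc4ncn(Cc5ccccc5)c4c3)n2)cc1` carries 4-ethylphenyl; in a functional assay on OVCAR-3 cells (Homo sapiens) for inhibition, read by sulforhodamine B assay, with a stated time of 48 h, tested at 10 uM (on this read-out lower numbers stand for less inhibition and higher numbers for more inhibition at the one concentration tested (going by the name of the read-out)), compound 1 gives 31.2%. Compound 2 `Cc1cccc(-c2cn3ccnc3c(-c3ccc4ncn(Cc5ccccc5)c4c3)n2)c1` carries 3-methylphenyl, and in this assay compound 2 gives 14%; the step of a number 17.2 percentage points lower from compound 1 to compound 2 (beyond the scatter) is the only one in the set that goes beyond the scatter. Compound 3 `O=Cc1ccc(-c2cn3ccnc3c(-c3ccc4ncn(Cc5ccccc5)c4c3)n2)cc1` carries 4-formylphenyl, and in this assay compound 3 gives 23.7%. On the raw numbers compound 3 stands second highest of the three, but the step of a number 7.5 percentage points lower from compound 1 to compound 3 (within the scatter) and the step of a number 9.7 percentage points higher from compound 2 to compound 3 (within the scatter) both lie within the scatter, so compound 3 cannot be separated from either of the others with confidence.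

Compound 4 `c1ccc(Cn2cnc3ccc(-c4nc(-c5cccc6ccccc56)cn5ccnc45)cc32)cc1` is not yet measured. Its change from compound 3 is naphthalen-1-yl in place of 4-formylphenyl on an aromatic carbon. For the measured compounds named here, no measured step replaces a phenyl group by a naphthalen-1-yl, so none bears directly on this change. The aryl swaps seen so far, one modest and two within the scatter, point to a small movement in this assay with no direction settled. Compound 4 is therefore expected at 25%, with a range from 8% to 42%. The estimated step of a number 1.3 percentage points higher from compound 3 to compound 4 (within the scatter) is expected to stay within the scatter.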

Compound 4, a percentage reported as inhibition, at one concentration (the size of the read-out at that concentration, not a potency): 1.44%
Compound 4: middle estimate off by 23.6 percentage points, on the high side; the whole stated range lies above it.
By their numbers in this assay, from the lowest: compound 4; then compounds 2, 3 and 1 (each within the scatter of the next, the first and the last beyond it).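

The naphthalen-1-yl group separates from all three earlier aryl groups at this position in this assay, with a number 22.3 percentage points lower from compound 3 to compound 4 (beyond the scatter), a number 12.6 percentage points lower from compound 2 to compound 4 (beyond the scatter) and a number 29.8 percentage points lower from compound 1 to compound 4 (beyond the scatter), so compound 4 has the lowest number of the four at the one concentration tested. Among the earlier compounds, which each carry a single six-membered aromatic ring of carbon only at this carbon, just one step went beyond the scatter; the read-out at this position can therefore move clearly downward when that ring gives way to naphthalen-1-yl, with its two such rings. Nothing available accounts for this drop.

A single compound cannot show whether the lower number goes with the second ring itself or with the way it is attached, and naphthalen-2-yl or unsubstituted phenyl at the same carbon would help to separate those two readings. From the compounds shown here alone, it also remains open whether any group here can lift the read-out well beyond that of compound 1 at 31.2%, for instance 4-aminophenyl or 4-carboxyphenyl, and how these single-concentration numbers relate to potency.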